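This account rests on a few compounds, and the source may have more. Where it says the series, first, only, none or still open, it means among the compounds named here.

Compound 1 `Nc1cc(N)c2nc(-c3ccccc3)c(Oc3ccc(Cl)c(Cl)c3)nc2c1` was tested in a functional assay on UACC-62 cells (Homo sapiens) for inhibition, read by sulforhodamine B assay, with a stated time of 48 h (a higher number here means a weaker inhibitor of growth, a lower number a stronger inhibitor of growth), and gave 47900 nM. Among the measured compounds shown here, of the two numbers known here, that is the higher one; the other compound measured, compound 2 `CCOC(=O)[C@H](CCC(=O)O)NC(=O)c1ccc(Oc2nc3cc(N)cc(N)c3nc2-c2ccccc2)cc1`, gave 30900 nM in this assay, and the gap between compound 1 and compound 2 lies within the ordinary scatter of this kind of measurement, so the two cannot be told apart. The compound still to be tested, compound 3 `Nc1cc(N)c2nc(-c3ccccc3)c(Oc3ccc(F)cc3)nc2c1`, differs from compound 1 in one place only: 4-fluorophenyl in place of 3,4-dichlorophenyl on an oxygen on an aromatic ring. For the measured compounds named here, no measured pair among the known compounds shows what this particular swap does, so there is no step to lean on. The expectation is therefore a step from compound 1 to compound 3 of a 1.1-fold higher number from compound 1 to compound 3 (0.06 log units; within the scatter), which means no change beyond the scatter. For compound 3 in this assay the estimated value is 55000 nM, with a range from 18000 nM to 160000 nM.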

Compound 3, concentration for total growth inhibition: 33100 nM
For compound 3 the middle estimate is 1.7-fold (0.22 log units) above the measured one, and the stated range covers the measured number.
By their numbers in this assay, from the lowest: compounds 2, 3 and 1 (each within the scatter of the next).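

In this assay, among the compounds shown here, the change from 3,4-dichlorophenyl to 4-fluorophenyl on the oxygen gives a 1.4-fold lower number from compound 1 to compound 3 (0.16 log units; within the scatter) and is the first direct reading of a swap at this position. The step cannot be told from no change, so these two groups give the same result within the scatter, even though the swap removes two chlorine atoms and adds one fluorine atom while the six-membered aromatic ring stays. Nothing measured here explains why the two groups read alike.

The compounds shown leave open whether a phenyl ring carrying an amine or a carboxylic acid would move the number beyond the scatter. As far as these compounds go, it also remains open whether a simple alkyl chain in place of the ring on this oxygen would do so.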